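The source may report more compounds than this note shows. Statements on the series, on what has been measured and on what is new or still open speak of the compounds shown alone.

The account starts from compound 1 `Cc1cc(NC(=O)Cn2nnc(-c3ccccc3)n2)n(C2CCC(C)(C)CC2)n1`. In an assay on HEK293 cells for activation of Kir3.1/Kir3.2 (Homo sapiens), read by thallium flux (on this read-out higher numbers stand for an effect only at larger amounts of compound and lower numbers for an effect already at smaller amounts), compound 1 returns only a limit, > 221 nM, so its standing is known as a bound rather than as a number. Among the two values shown, compound 1 stands at the limit of > 221 nM in this assay, at which 1 of the 2 values shown sits. The only companion measured alongside it is compound 2 `O=C(Cn1nnc(-c2ccccc2)n1)Nc1cc(C2CC2)nn1C1CCCCC1`, which in this assay gives 271 nM. Compound 2 differs from compound 1 in more than one place, so its value shows only where a related structure lands, not what any single change does. The unmeasured compound 3 `Cc1cc(NC(=O)Cn2nnc(-c3ccccc3)n2)n(CC2CCCCC2)n1` arises from compound 1 by one exchange: cyclohexylmethyl in place of 4,4-dimethylcyclohexyl on an aromatic nitrogen. Among the measured compounds shown here, no step between measured compounds is known for an exchange of this kind, so there is no measured precedent. Because compound 1 carries only the limit > 221 nM, the size of the step cannot be fixed from the numbers. Compound 3 is expected to land in the same general region, with the step that the limit leaves unreadable from compound 1 to compound 3 carrying little confidence and perhaps not exceeding the scatter. Compound 3 is estimated at 500 nM, within a range from 150 nM to 3000 nM.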

Compound 3, half-maximal effective concentration: 176 nM
The estimate for compound 3 lay 2.8-fold (0.45 log units) above the measured number; measured number inside the range.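

Compound 1 holds only a limit and not a number: the limit of > 221 nM in this assay, at which 1 of the 3 values shown sits. The exchange of 4,4-dimethylcyclohexyl for cyclohexylmethyl on the aromatic nitrogen gives this position its first step in this assay, namely an at least 1.2-fold lower number from compound 1 to compound 3 (0.09 log units; that floor lies within the scatter); this is only a floor, so the true step may stay within the scatter or may prove larger. What is new is that compound 3 gives 176 nM with the rest of the structure unchanged, so on this core, cyclohexylmethyl at this position yields a measured number rather than a limit.

The compounds shown leave open how far the true step reaches past that floor, and which part of the exchange matters: the loss of the two methyl groups on the ring or the arrival of the cyclohexylmethyl link, which a plain cyclohexyl on this same core would help to separate. They also leave open how this position responds to a longer chain such as cyclohexylethyl, or to a ring carrying an amine or a carboxylic acid.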